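The compounds below may be only part of what the source reports. "The series", "measured", "known", "first", "only" and "open" are said of these compounds alone.

Measured compounds:
- Compound 1 `CCCCC[C@@H](C(=O)NCNC(=O)c1ccc(-c2ccc(C(=O)O)c(OCC)c2)o1)[C@@H](CC)N(O)C=O`: < 1 nM
- Compound 2 `CCCCC[C@H](CN(O)C=O)C(=O)NCNC(=O)c1ccc(-c2ccccc2)o1`: 25 nM
- Compound 3 `CCCCC[C@H](CN(O)C=O)C(=O)NCNC(=O)c1ccc(-c2cccc(C(=O)O)c2)o1`: 8 nM

In an assay on CHO cells for inhibition of bone morphogenetic protein 1 (Homo sapiens), with stated times of 10 min and 60 min (a higher number here means a weaker inhibitor, a lower number a stronger inhibitor), compound 1 gives < 1 nM, which is a limit of the assay rather than a number. Compound 3 has the lowest of the two actual numbers; its nearest neighbour is compound 2, and the step of a 3.1-fold lower number from compound 2 to compound 3 (0.49 log units; beyond the scatter) lies beyond the scatter. Compound 4 `CCCCC[C@H](CN(O)C=O)C(=O)NCNC(=O)c1ccc(-c2cccc(OCC)c2)o1` differs from compound 3 by ethoxy in place of carboxy on an aromatic carbon. Going by the values given here, only one measured step bears on this: the gain seen as a 3.1-fold lower number from compound 2 to compound 3 (0.49 log units; beyond the scatter) came from adding the carboxy, and compound 4 removes that carboxy again while bringing in ethoxy. The number is therefore expected to rise, a 2.5-fold higher number from compound 3 to compound 4 (0.40 log units; beyond the scatter), towards that of compound 2. Compound 4 is estimated at 20 nM, with a range from 6 nM to 60 nM.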

Compound 4, half-maximal inhibitory concentration: 1 nM
Beside the measured number, compound 4's estimate is 20-fold (1.30 log units) above it; the whole stated range lies above it.
By their numbers in this assay, from the lowest: compound 4; then compound 3; then compound 2.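

In this assay, the earlier gain from carboxy did not mean that only carboxy works at this place, meta to a large group: ethoxy goes further, with an 8.0-fold lower number from compound 3 to compound 4 (0.90 log units; beyond the scatter). Against plain hydrogen, ethoxy gives a 25-fold lower number from compound 2 to compound 4 (1.40 log units; beyond the scatter), so among these three compounds the group with no hydrogen-bond donor gives the lowest number. Compound 4 also lies close to a limit of the read-out: the limit of < 1 nM in this assay, at which 1 of the 4 values shown sits. Going by these compounds, whether a methoxy, a longer alkoxy chain or an amine would serve as well here stays open. So does whether ethoxy would work elsewhere on this ring.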